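A few compounds are considered here, and "the series" means these few. Any claim that something is new, unique, unknown or untested is made for them only; others in the source may bear on it.

Of the compounds shown here, three with the same core have been measured in a functional assay on MCF7 cells (Homo sapiens) for antiproliferative activity, read by MTT assay, with a stated time of 48 h; a higher number here means a weaker inhibitor, a lower number a stronger inhibitor. In it, compound 1 (`O=C(/C=C/c1ccc(O)c(O)c1)N1CCN(c2ccccc2F)CC1`) gives 1.38 ug/mL, compound 2 (`COc1ccccc1N1CCN(C(=O)/C=C/c2ccc(O)c(O)c2)CC1`) gives 0.54 ug/mL and compound 3 (`Cc1ccc(N2CCN(C(=O)/C=C/c3ccc(O)c(O)c3)CC2)c(C)c1`) gives 0.78 ug/mL. Compound 3 cannot be separated from either of the others, as the data show a 1.8-fold lower number from compound 1 to compound 3 (0.25 log units; within the scatter) and a 1.4-fold higher number from compound 2 to compound 3 (0.16 log units; within the scatter). Only a 2.6-fold lower number from compound 1 to compound 2 (0.41 log units; beyond the scatter) clears the scatter, and it is modest.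

Compound 4 (`O=C(/C=C/c1ccc(O)c(O)c1)N1CCN(c2ccc(Cl)c(Cl)c2)CC1`) has not yet been measured. It carries 3,4-dichlorophenyl in place of 2,4-dimethylphenyl on an amine nitrogen in a ring. All three measured steps are changes to the group at this same place, so they are the relevant guide, and the largest of them is a 2.6-fold lower number from compound 1 to compound 2 (0.41 log units; beyond the scatter). Within the data shown here, none of the measured compounds contains chlorine, so the data do not cover this group directly. Among the measured compounds shown here, compound 1, which holds a fluoro group and gives 1.38 ug/mL, is the only measured compound with a halogen, and that is a slight reason to lean towards its number. The step expected in this assay is therefore small and upward, with none expected beyond the scatter: a 1.3-fold higher number from compound 3 to compound 4 (0.11 log units; within the scatter). For compound 4 the estimated value is 1 ug/mL, with an expected range from 0.4 ug/mL to 2.5 ug/mL.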

Compound 4, half-maximal inhibitory concentration: 1.28 ug/mL
For compound 4 the middle estimate is 1.3-fold (0.11 log units) below the measured one, and the stated range covers the measured number.
By their numbers in this assay, from the lowest: compounds 2, 3, 4 and 1 (each within the scatter of the next, the first and the last beyond it).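

In this assay, among these compounds, the only chlorine-bearing group seen at this place, 3,4-dichlorophenyl, cannot be separated from 2,4-dimethylphenyl (a 1.6-fold higher number from compound 3 to compound 4 (0.22 log units; within the scatter)) or from 2-fluorophenyl (a 1.1-fold lower number from compound 1 to compound 4 (0.03 log units; within the scatter)), so neither the two chlorines nor the swap of one halogen-bearing phenyl for another gives a readable change here. Only the comparison with 2-methoxyphenyl clears the scatter (a 2.4-fold higher number from compound 2 to compound 4 (0.37 log units; beyond the scatter)), and it is modest; with the earlier step to compound 2 from compound 1, this sets compound 2 apart from both halogen-bearing compounds, while compound 3 remains inseparable from all the others. No evidence is available that bears on why these groups compare as they do.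

Going by these compounds, all four compounds keep a substituted phenyl on the ring nitrogen, so it remains open what a single chlorine as in 4-chlorophenyl, a pyridine ring, a benzyl group or a cyclohexyl group would give at this place. The other end of the shared core does not vary among them either, which leaves open what methoxy groups in place of its two hydroxy groups would do.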